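This account rests on a few compounds, and the source may have more. Where it says the series, first, only, none or still open, it means among the compounds named here.

Working notes on the series.

Within the data shown here, compound 1, `CC(C)(C)Cc1c(-c2cccc(F)c2F)sc(N)c1C(=O)c1ccc(Cl)cc1`, is the first member with a number. In an assay on CHO cells for displacement of a labelled ligand from adenosine receptor A1 (Homo sapiens), read by scintillation counting, tested at 10 uM (a higher number here means more inhibition at the concentration tested (going by the name of the read-out), a lower number less inhibition), compound 1 gives 1%, a low degree of inhibition at the concentration tested. Compound 2, `COCCOc1ccc(-c2sc(N)c(C(=O)c3ccc(Cl)cc3)c2CC(C)(C)C)cc1`, carries a 2-methoxyethoxy group on the aromatic ring attached to the shared core. In this assay compound 2 gives 1%, level with compound 1 at the digits shown, so the two values lie within the usual scatter of each other and no order between them can be read.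

Compound 3, `CC(C)(C)Cc1c(-c2ccccc2)sc(N)c1C(=O)c1ccc(Cl)cc1`, has not yet been measured. Its difference from compound 2 is hydrogen in place of 2-methoxyethoxy on an aromatic carbon. Among the measured compounds shown here, with both measured compounds sitting at the same low inhibition, no step from compound 2 to compound 3 beyond the scatter is expected in this assay, in either direction. The expected step is a number 1 percentage points higher from compound 2 to compound 3 (within the scatter). For compound 3 the estimate in this assay is 2%, with a range from 0% to 12%.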

Compound 3, a percentage reported as inhibition, at one concentration (the size of the read-out at that concentration, not a potency): 1%
Estimate against measurement, compound 3: 1 percentage points above; the measured number falls inside the stated range.
By their numbers in this assay, from the lowest: compounds 1, 2 and 3 (each within the scatter of the next).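

In this assay, hydrogen in place of 2-methoxyethoxy on an aromatic carbon, para to a large group, gives no change at the digits printed from compound 2 to compound 3 (within the scatter) and leaves the position without any substituent on that ring. Phenyl in place of 2,3-difluorophenyl gives no change at the digits printed from compound 1 to compound 3 (within the scatter) on the same comparison, so the unsubstituted phenyl now serves as a reference, and neither the 2-methoxyethoxy group nor the two fluorines can be told apart from it at this single test concentration. What had been a comparison of two differently substituted rings thus becomes a statement about each substituent against hydrogen, and all three compounds remain at the same low inhibition. No measurement bearing on the cause of this result is available.

The compounds shown leave open whether any group on this aromatic ring would lift the reading clear of the scatter, for instance an amine or a carboxylic acid at the place held by 2-methoxyethoxy, or a longer chain there. They also leave open whether the same holds for a group other than phenyl on the shared core, such as a pyridine ring.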